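Swapping an Ester for an Amide at the Assay Limit

The source may report more compounds than this note shows. Statements on the series, on what has been measured and on what is new or still open speak of the compounds shown alone.

- compound 1 `CCCCc1cc2c(=O)c(C(=O)OCC)c[nH]c2cc1OCCOc1ccccc1`: > 20000 nM, a limit
- compound 2 `COC(=O)c1c[nH]c2ccc(Cl)cc2c1=O`: > 20000 nM, a limit
- compound 3 `CCCCc1ccc2[nH]ccc(=O)c2c1`: > 20000 nM, a limit

These readings come from an ADME assay on J774 cells (Mus musculus) for cytotoxicity; on this read-out lower numbers stand for an effect already at smaller amounts and higher numbers for an effect only at larger amounts of compound. None of them is an exact number. Compound 1 stands at > 20000 nM, which is a limit of the assay. It shares that position with the other two compounds, as the full set shows: the limit of > 20000 nM in this assay, at which 3 of the 3 values shown sit.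

Compound 4 `CCCCc1cc2c(=O)c(C(=O)NCC)c[nH]c2cc1OCCOc1ccccc1` has not yet been measured. It has ethylamino in place of ethoxy on a carbonyl carbon, so that ethoxycarbonyl becomes ethylcarbamoyl (ethylamino in place of ethoxy on a carbonyl carbon). For the measured compounds named here, no pair of measured compounds shows what a change of this kind does, which leaves the size of the step uncertain. Going by the values given here, with the limit of > 20000 nM in this assay, at which 3 of the 3 values shown sit, as the only guide, the expected change is small and has no firm direction, and it may not go beyond the usual scatter. The estimated move is a number no higher from compound 1 to compound 4 (the limit leaves the size open). For compound 4 the expected value is 20000 nM, within an estimated range of 8000 nM to 40000 nM.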

Compound 4, half-maximal effective concentration: > 20000 nM
Compound 4: a limit, no number (the forecaster's own chance of this, stated with the estimate: 75%); the middle value sits exactly at the limit.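

Compound 1 and compound 4 each give only a limit, so no step between them can be read: the limit of > 20000 nM in this assay, at which 4 of the 4 values shown sit.

The compounds shown leave open whether ethylamino in place of ethoxy changes anything in this assay, and at what amount any of these compounds would show an effect.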